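Dropping the ring methyl from compound 2

The compounds below may be only part of what the source reports. "The series", "measured", "known", "first", "only" and "open" are said of these compounds alone.

In a functional assay on SF-295 cells (Homo sapiens) (a higher number here means a weaker inhibitor of growth, a lower number a stronger inhibitor of growth), compound 2 `COc1cccc(-c2cc(O)c3cc(C)cnc3n2)c1` gives 37.2 nM, the lowest of the three numbers. Compound 1 `COc1ccc(-c2cc(O)c3cc(C)cnc3n2)cc1` gives 5250 nM, and compound 3 `Cc1cnc2nc(-c3ccc(F)cc3)cc(O)c2c1` gives 29500 nM. Compound 4 `COc1cccc(-c2cc(O)c3cccnc3n2)c1` differs from compound 2 by hydrogen in place of methyl on an aromatic carbon. Among the measured compounds shown here, the one measured step, a 5.6-fold higher number from compound 1 to compound 3 (0.75 log units; beyond the scatter), exchanges methoxy for fluoro and leaves the methyl untouched, so it offers only a rough guide to size and no direct measure of this change. With compound 2 at 37.2 nM, a higher number is the likelier direction. The estimated step is a 4.0-fold higher number from compound 2 to compound 4 (0.61 log units; beyond the scatter), of modest size. Compound 4 is expected at 150 nM, within an estimated range of 30 nM to 1000 nM.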

Compound 4, concentration for 50% growth inhibition: 52.5 nM
Beside the measured number, compound 4's estimate is 2.9-fold (0.46 log units) above it; the measured number falls inside the stated range.
By their numbers in this assay, from the lowest: compounds 2 and 4 (each within the scatter of the next); then compound 1; then compound 3.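

In this assay the exchange of methyl for hydrogen on this aromatic carbon, two atoms from the ring nitrogen, gives a 1.4-fold higher number from compound 2 to compound 4 (0.15 log units; within the scatter) and so does not separate the two groups. Among the compounds shown here, compounds 1, 2 and 3 all carry the methyl, so only this pair reads the position, and with the methoxy placement of compound 2 held fixed the methyl is not needed for a low number. No evidence on the cause accompanies this result.

On these data alone, whether hydrogen and methyl also match with the aryl groups of compound 1 and compound 3 stays open. So does how an ethyl group or an amine would read at this position.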